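Benzylamino for methoxy: the step to compound 4

This account rests on a few compounds, and the source may have more. Where it says the series, first, only, none or still open, it means among the compounds named here.

In a physicochemical assay for solubility, in phosphate buffer, at pH 6.5 (a lower number here means a less soluble compound, a higher number a more soluble compound), compound 1 `C=C[C@@H]1C[C@]1(NC(=O)[C@@H]1C[C@@H](Oc2nccc3cc(OC)ccc23)CN1C(=O)[C@@H](NC(=O)N[C@@H](C)COC)C(C)(C)C)C(=O)NS(=O)(=O)C1CC1` reads 1070 ug/mL and compound 2 `C=C[C@@H]1C[C@]1(NC(=O)[C@@H]1C[C@@H](Oc2nccc3cc(OC)ccc23)CN1C(=O)[C@@H](NC(=O)N[C@H](COC)CC(C)C)C(C)(C)C)C(=O)NS(=O)(=O)C1CC1` reads 225 ug/mL, while compound 3 `C=C[C@@H]1C[C@]1(NC(=O)[C@@H]1C[C@@H](Oc2nccc3cc(OC)ccc23)CN1C(=O)[C@@H](NC(=O)N[C@H](C(=O)OC)C(C)(C)C)C(C)(C)C)C(=O)NS(=O)(=O)C1CC1` reads 754 ug/mL and is placed by two steps (a 1.4-fold lower number from compound 1 to compound 3 (0.15 log units; within the scatter)) and (a 3.4-fold higher number from compound 2 to compound 3 (0.53 log units; beyond the scatter)). Compound 4 `C=C[C@@H]1C[C@]1(NC(=O)[C@@H]1C[C@@H](Oc2nccc3cc(OC)ccc23)CN1C(=O)[C@@H](NC(=O)N[C@H](C(=O)NCc1ccccc1)C(C)(C)C)C(C)(C)C)C(=O)NS(=O)(=O)C1CC1` carries benzylamino in place of methoxy on a carbonyl carbon. Within the data shown here, no measured step makes this change. The nearest guide is the isopropyl addition (a 4.8-fold lower number from compound 1 to compound 2 (0.68 log units; beyond the scatter)), though the exchange leading from compound 1 to compound 3 stayed within the scatter. A modest fall is therefore expected (a 3.0-fold lower number from compound 3 to compound 4 (0.48 log units; beyond the scatter)). In this assay the expected value for compound 4 is 250 ug/mL within an estimated range (80 ug/mL to 700 ug/mL).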

Compound 4, solubility: 95 ug/mL
For compound 4 the middle estimate is 2.6-fold (0.42 log units) above the measured one; the range from low to high includes it.
By their numbers in this assay, from the lowest: compound 4; then compound 2; then compounds 3 and 1 (each within the scatter of the next).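

In this assay, benzylamino in place of methoxy on a carbonyl carbon gives a 7.9-fold lower number from compound 3 to compound 4 (0.90 log units; beyond the scatter), the first change shown at this carbonyl carbon. The methoxycarbonyl group of compound 3 had left the number within the scatter of compound 1, so this step shows that the same site can also carry a change that lies beyond the scatter. Nothing shown gives a reason for this fall.

Benzylamino brings in both an aromatic ring and an amide hydrogen, and this single step does not separate the two. A methylamino or dimethylamino group on the same carbonyl carbon would begin to do so.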